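Isopropyl in place of cyclohexylmethyl on the ring amine nitrogen

The source may hold more compounds than are shown below. What is called first, only, known or untested is meant among the compounds shown, and "the series" means these compounds.

Compound 2 `NC(=O)c1c(NC(=O)Nc2ccc(Cl)cc2)sc2c1CCN(CC1CCCCC1)C2` stands second highest of three numbers in a functional assay (strain AB) with Danio rerio as the target, read by microscopy, with a stated time of 1 h; on this read-out higher numbers stand for an effect only at larger amounts of compound and lower numbers for an effect already at smaller amounts: compound 2 gives 1890 nM, compound 3 `CC(C)C[N+]1(C)CCc2c(sc(NC(=O)Nc3ccc(Cl)cc3)c2C(N)=O)C1` gives 380 nM, a lower number beyond the scatter, and compound 1 `CCN1CCc2c(sc(NC(=O)Nc3cccc(Cl)c3Cl)c2C(N)=O)C1` gives 17400 nM, a higher number beyond the scatter. Compound 4 `CC(C)N1CCc2c(sc(NC(=O)Nc3ccc(Cl)cc3)c2C(N)=O)C1` has not yet been measured. It differs from compound 2 in one place: isopropyl in place of cyclohexylmethyl on an amine nitrogen in a ring. Among the measured compounds shown here, no measured pair isolates this change, and compounds 1 and 3 differ from compound 2 in more than this one place, so the direction rests on weak ground. A modest step toward a higher number is expected, with a wide margin. Compound 4 is estimated at 4500 nM in this assay, between 1200 nM and 17000 nM. The expected step is a 2.4-fold higher number from compound 2 to compound 4 (0.38 log units; beyond the scatter).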

Compound 4, half-maximal effective concentration: 1490 nM
Beside the measured number, compound 4's estimate is 3.0-fold (0.48 log units) above it; the range from low to high includes it.
By their numbers in this assay, from the lowest: compound 3; then compounds 4 and 2 (each within the scatter of the next); then compound 1.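

Putting isopropyl in place of cyclohexylmethyl on the amine nitrogen in a ring gives a 1.3-fold lower number from compound 2 to compound 4 (0.10 log units; within the scatter) in this assay. This first pair isolating the change shows that, with the rest of the structure held constant, the two groups cannot be told apart on this read-out, although the six-membered carbon ring leaves and the group shrinks. No measured evidence bears on why they read alike. Still open, going by these compounds, is whether a benzyl group, a longer chain ending in an amine or one ending in a carboxylic acid on this nitrogen would also leave the number unchanged.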